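Hydrogen in place of ethyl on the amide nitrogen

This account rests on a few compounds, and the source may have more. Where it says the series, first, only, none or still open, it means among the compounds named here.

Three compounds sharing one core have been run in a functional assay on the whole organism with Mus musculus as the target; on this read-out lower numbers stand for an effect already at smaller amounts and higher numbers for an effect only at larger amounts of compound. Compound 1 `CN(C)C(=O)/C=C1\CCc2c(F)cc(F)cc21` gives 50 mg/kg, compound 2 `CCNC(=O)/C=C1\CCc2ccc(F)cc21` gives 70 mg/kg, and compound 3 `O=C(/C=C1\CCc2cc(F)ccc21)NC1CC1` gives 81 mg/kg. All three numbers lie within the usual scatter of one another, so no order among them can be read. Compound 2 stands second highest of the three, nearest to compound 3 and furthest from compound 1, with both gaps inside the scatter. Among the measured compounds shown here, the measured compounds differ from each other in more than one place, so no single step between measured compounds is available.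

Compound 4 `NC(=O)/C=C1\CCc2ccc(F)cc21` has not yet been measured in this assay. Its difference from compound 2, computed from the two structures, is hydrogen in place of ethyl on an amide-type nitrogen. Cut one bond further out the same change reads ethylamino to amino, ethylcarbamoyl to carbamoyl. For the measured compounds named here, no measured pair shows what this change does. Since the three measured compounds, carrying different groups on the amide-type nitrogen, all sit within the scatter of each other, there is no reason to expect a step beyond the scatter in either direction. Compound 4 is therefore expected to give about 80 mg/kg in this assay, within a range of 35 mg/kg to 180 mg/kg. The expected step of a 1.1-fold higher number from compound 2 to compound 4 (0.06 log units; within the scatter) is estimated to stay within the scatter.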

Compound 4, dose for half-maximal effect: 56 mg/kg
The estimate for compound 4 lay 1.4-fold (0.15 log units) above the measured number, and the stated range covers the measured number.
By their numbers in this assay, from the lowest: compounds 1, 4, 2 and 3 (each within the scatter of the next).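

In this assay, among the compounds shown here, hydrogen in place of ethyl on the amide-type nitrogen gives a 1.3-fold lower number from compound 2 to compound 4 (0.10 log units; within the scatter), the first reading of a single change at this position. Compounds 2 and 4 cannot be told apart on this read-out, so the ethyl group can be lost from this nitrogen with no step beyond the scatter, at least on the core these two compounds share. No measured property of either compound accompanies this result that could bear on it, and the step stands as a plain observation on the whole organism.

The compounds shown leave open whether any group on this nitrogen moves the number beyond the scatter, as a longer chain such as n-butyl, a chain ending in an amine or a chain ending in a carboxylic acid might; with only hydrogen and ethyl compared directly, the tolerance of this position is known over a narrow span. They also leave open whether hydrogen in place of ethyl reads the same on the cores of compound 1 and compound 3.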